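The source may report more compounds than this note shows. Statements on the series, on what has been measured and on what is new or still open speak of the compounds shown alone.

Measured in a physicochemical assay for solubility, read by spectrophotometry, in phosphate buffer, with a stated time of 18 h, at pH 7.4; a lower number here means a less soluble compound, a higher number a more soluble compound:
- compound 1 `CCc1ccc(-c2nc3c(c(C)nn3-c3ccccc3)c(-c3ccccc3Br)c2C#N)cc1` gives 1500 nM
- compound 2 `CCc1ccc(-c2nc3c(c(C)nn3-c3ccccc3)c(-c3ccccc3Cl)c2C#N)cc1` gives 1700 nM
- compound 3 `CCc1ccc(-c2nc3c(c(C)nn3-c3ccccc3)c(-c3ccccc3C)c2C#N)cc1` gives 6000 nM

Compound 1 and compound 2 stand together at the low end of these numbers, with a 1.1-fold higher number from compound 1 to compound 2 (0.05 log units; within the scatter). Compound 4 `CCc1ccc(-c2nc3c(c(C)nn3-c3ccccc3)c(-c3ccccc3S(C)(=O)=O)c2C#N)cc1` keeps the core of compound 1 but carries 2-(methylsulfonyl)phenyl instead of 2-bromophenyl: methylsulfonyl in place of bromo on an aromatic carbon.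

All three measured steps concern this same place on the molecule. Besides the step above, there are a 4.0-fold higher number from compound 1 to compound 3 (0.60 log units; beyond the scatter) and a 3.5-fold higher number from compound 2 to compound 3 (0.55 log units; beyond the scatter). These two are modest, and both lead to the methyl compound. Among the measured compounds shown here, no measured compound carries methylsulfonyl, so the steps show only that a change at this place has moved the number modestly in this assay. A modest step to a higher number is therefore expected, though with little certainty, and a step within the scatter would not be surprising.

The step expected is a 4.7-fold higher number from compound 1 to compound 4 (0.67 log units; beyond the scatter). For compound 4 the estimated value is 7000 nM, with an expected range of 2000 nM to 25000 nM.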

Compound 4, solubility: 2200 nM
The estimate for compound 4 lay 3.2-fold (0.50 log units) above the measured number; measured number inside the range.
By their numbers in this assay, from the lowest: compounds 1, 2 and 4 (each within the scatter of the next); then compound 3.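

In this assay methylsulfonyl on this aromatic carbon groups with bromo and chloro rather than with methyl: there is a 1.5-fold higher number from compound 1 to compound 4 (0.17 log units; within the scatter) and a 1.3-fold higher number from compound 2 to compound 4 (0.11 log units; within the scatter) but a 2.7-fold lower number from compound 3 to compound 4 (0.44 log units; beyond the scatter) on the methyl side. The higher number of compound 3 is therefore not shared by every replacement of the halogens here, and among these four groups compound 3 alone stands apart, since a group of four heavy atoms with two hydrogen-bond acceptors reads no differently from bromo or chloro. Nothing measured here offers an explanation for why methylsulfonyl reads with the halogens rather than with methyl.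

As far as these compounds go, what remains open is where an amine, a carboxylic acid or a longer chain at this place would fall. Also open, from the compounds shown here alone, is whether ethyl or methoxy would stay with methyl or join the other three groups.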